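Aryl ester of compound 1: expected outcome in cell assay

The source may hold more compounds than are shown below. What is called first, only, known or untested is meant among the compounds shown, and "the series" means these compounds.

Compound 1 `O=C(O)c1cn(-c2ccccc2)nc1-c1ccsc1` is the free acid of the series. In a functional assay on HL-60 cells (Homo sapiens) for inhibition, read by MTT assay, with a stated time of 48 h (on this read-out higher numbers stand for weaker inhibition and lower numbers for stronger inhibition), compound 1 gives > 100000 nM, which is a limit of the assay and not a measured number. Compound 2 `O=C(NCc1ccccc1)c1cn(-c2ccccc2)nc1-c1ccsc1` carries the benzylamide. In this assay compound 2 gives > 100000 nM, again a limit. Compound 3 `CCc1ccc(OC(=O)c2cn(-c3ccccc3)nc2-c2ccsc2)cc1` is the 4-ethylphenyl ester. In this assay compound 3 gives > 100000 nM, also a limit. Between the measured compounds there is a step that the two limits leave unreadable from compound 1 to compound 2, a step that the two limits leave unreadable from compound 1 to compound 3 and a step that the two limits leave unreadable from compound 2 to compound 3; none of these can be sized since every value sits at the limit of > 100000 nM in this assay, at which 3 of the 3 values shown sit.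

Compound 4 `CC(C)c1cccc(OC(=O)c2cn(-c3ccccc3)nc2-c2ccsc2)c1` differs from compound 1 by 3-isopropylphenyl in place of hydrogen on an oxygen next to a carbonyl group. The closest measured change is the ester formation toward compound 3, and that step was unreadable, so no direction can be expected beyond the scatter. In this assay compound 4 is expected to give 100000 nM, within 30000 nM to 300000 nM. The estimated step is a number no higher from compound 1 to compound 4 (the limit leaves the size open), most likely reported only as the same limit once more.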

Compound 4, half-maximal inhibitory concentration: > 100000 nM
Compound 4 ended at the assay's limit (the forecaster's own chance of this, stated with the estimate: 85%); the middle value sits exactly at the limit.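

No new step can be read in this assay for compound 4 against compound 1 or compound 3, as all of these compounds sit at one limit: the limit of > 100000 nM in this assay, at which 4 of the 4 values shown sit.

The compounds shown leave open whether any group on this carbonyl carbon gives a measurable value in this assay at all.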